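The source may hold more compounds than are shown below. What is called first, only, known or untested is meant among the compounds shown, and "the series" means these compounds.

Measured so far in an ADME assay on microsomes from liver (Homo sapiens) for metabolic stability, tested at 2.5 uM; a lower number here means slower removal, a higher number faster removal of the compound:
compound 1 `COc1ccc(S(=O)(=O)c2cnc3c(F)cccc3c2-c2ccc(Cl)cc2)cc1`: 1.05 mL/min
compound 2 `COc1cccc(-c2c(S(=O)(=O)c3cc(F)cc(F)c3)cnc3c(F)cccc23)c1`: 2.76 mL/min
compound 3 `O=S(=O)(c1cccc(F)c1)c1cnc2c(F)cccc2c1-c1ccc(Cl)cc1`: 0.62 mL/min

Compound 3 gives the lowest of the three numbers; its gap to compound 1 lies within the scatter, its gap to compound 2 beyond it. Compound 4 `O=S(=O)(c1cc(F)cc(F)c1)c1cnc2c(F)cccc2c1-c1ccc(Cl)cc1` is not yet measured. It differs from compound 3 by fluoro in place of hydrogen on an aromatic carbon. For the measured compounds named here, the only measured step touching the group on the sulfonyl sulfur is a 1.7-fold lower number from compound 1 to compound 3 (0.23 log units; within the scatter), a change of a different kind, so it bears on this step only loosely. Compound 2 also carries a 3,5-difluorophenyl on the sulfonyl sulfur, but with a different group on the shared core, so its value cannot be read as this step alone. No step beyond the scatter is expected. Compound 4 is estimated at 0.9 mL/min, range 0.45 mL/min to 1.8 mL/min. The expected step is a 1.5-fold higher number from compound 3 to compound 4 (0.16 log units; within the scatter).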

Compound 4, intrinsic clearance in a liver preparation (reported as CLH), per the amount of preparation that the assay uses: 0.73 mL/min
Compound 4: middle estimate off by 1.2-fold (0.09 log units), on the high side, and the stated range covers the measured number.
By their numbers in this assay, from the lowest: compounds 3, 4 and 1 (each within the scatter of the next); then compound 2.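

In this assay, fluoro in place of hydrogen, turning 3-fluorophenyl into 3,5-difluorophenyl on the sulfonyl sulfur, leaves the number within the scatter (a 1.2-fold higher number from compound 3 to compound 4 (0.07 log units; within the scatter)). Putting 3,5-difluorophenyl in place of 4-methoxyphenyl on that sulfur also stays within the scatter (a 1.4-fold lower number from compound 1 to compound 4 (0.16 log units; within the scatter)). For the compounds shown here, with 3,5-difluorophenyl held fixed, 4-chlorophenyl in place of 3-methoxyphenyl gives the only new step beyond the scatter (a 3.8-fold lower number from compound 2 to compound 4 (0.58 log units; beyond the scatter)).

Nothing shown accounts for any of these steps. Still open, on these data alone, is whether an amine or a carboxylic acid on the sulfonyl sulfur's phenyl group would shift the number.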